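The source may hold more compounds than are shown below. What is called first, only, known or untested is meant among the compounds shown, and "the series" means these compounds.

Of the compounds shown here, three of one family have been measured in a functional assay on MIA PaCa-2 cells (Homo sapiens) for inhibition, read by MTT assay, with a stated time of 72 h; a higher number here means a weaker inhibitor of growth, a lower number a stronger inhibitor of growth. Compound 1 `O=S(=O)(NCCCNCc1ccc(Cl)c(C(F)(F)F)c1)c1cc(C(F)(F)F)cc(C(F)(F)F)c1` gives 7400 nM in this assay. Compound 2 `O=S(=O)(NCCCCCCNCc1ccc(Br)cc1)c1ccc2c(c1)OCC2` gives 13000 nM in this assay. Compound 3 `CC(C)c1ccc(S(=O)(=O)NCCCCCCNCc2ccc(Br)cc2)cc1` gives 5730 nM in this assay, the lowest number of the three, though its gap to compound 1 lies within the scatter of repeated measurements, so no order between those two can be claimed.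

Among the compounds with values here, the only step between measured compounds that differ in one place is a 2.3-fold lower number from compound 2 to compound 3 (0.36 log units; beyond the scatter), which exchanged the group carried on the sulfonyl sulfur.

Compound 4 `Cc1ccc(S(=O)(=O)NCCCCCCNCc2ccc(Br)cc2)cc1` differs from compound 3 by methyl in place of isopropyl on an aromatic carbon of the ring bound to the sulfonyl sulfur. Within the data shown here, no measured step changes exactly this part of the shared core; the step of a 2.3-fold lower number from compound 2 to compound 3 (0.36 log units; beyond the scatter) shows only that this ring matters to a modest degree. Compound 4 is therefore expected to give about 9000 nM, with a range from 4000 nM to 20000 nM. The expected step is a 1.6-fold higher number from compound 3 to compound 4 (0.20 log units; within the scatter), which may well remain within the scatter.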

Compound 4, concentration for 50% growth inhibition: 12300 nM
Estimate against measurement, compound 4: 1.4-fold (0.14 log units) below, and the stated range covers the measured number.
By their numbers in this assay, from the lowest: compounds 3, 1, 4 and 2 (each within the scatter of the next, the first and the last beyond it).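

Until now the group on the sulfonyl sulfur had only been exchanged as a whole; here, in this assay, the change from 4-isopropylphenyl to 4-methylphenyl alone gives a 2.1-fold higher number from compound 3 to compound 4 (0.33 log units; beyond the scatter), so altering this one small group is enough to move the number, if only modestly. The group of compound 2 and the 4-methylphenyl group cannot be told apart, with a 1.1-fold lower number from compound 2 to compound 4 (0.02 log units; within the scatter), so among these three compounds the lower number goes with isopropyl alone. Nothing measured here bears on the reason for this step.

On these data alone, whether a tert-butyl or cyclohexyl group in place of isopropyl would lower the number further remains open. So does whether the isopropyl step would hold with a nitrile in place of the bromine on the other ring.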